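The source may hold more compounds than are shown below. What is called first, only, known or untested is meant among the compounds shown, and "the series" means these compounds.

Compound 2 `CN(C)c1cc2[nH]c(C3CCCCC3)nc2cc1NC(=O)OCC(F)(F)F` is the compound the step starts from. In an ADME assay on Vero cells (Chlorocebus sabaeus) for cytotoxicity, read by resazurin assay, with a stated time of 3 days (on this read-out lower numbers stand for stronger inhibition and higher numbers for weaker inhibition), compound 2 gives > 100 ug/mL, which is a limit of the assay and not a number. Two close relatives share its core: compound 1 `CCN(CC)c1cc2[nH]c(C3CCCCC3)nc2cc1NC(=O)OCC(F)(F)F` and compound 3 `O=C(Nc1cc2nc(C3CCCCC3)[nH]c2cc1N1CCCC1)OCC(F)(F)F`. In this assay compound 1 gives > 100 ug/mL, again a limit. In this assay compound 3 gives > 100 ug/mL, also a limit. Because (the limit of > 100 ug/mL in this assay, at which 3 of the 3 values shown sit), the steps a step that the two limits leave unreadable from compound 1 to compound 2, a step that the two limits leave unreadable from compound 1 to compound 3 and a step that the two limits leave unreadable from compound 2 to compound 3 cannot be sized. Compound 4 `CN(C)c1cc2[nH]c(C3CCCCC3)nc2cc1NC(=O)c1ccc(F)cc1` differs from compound 2 by 4-fluorophenyl in place of 2,2,2-trifluoroethoxy on a carbonyl carbon. For the measured compounds named here, none of the measured steps involves a change on a carbonyl carbon, so none bears on this one. The step of a number no higher from compound 2 to compound 4 (the limit leaves the size open) is therefore expected without support from measured steps. Compound 4 is estimated at 100 ug/mL, between 30 ug/mL and 200 ug/mL.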

Compound 4, half-maximal inhibitory concentration: > 100 ug/mL
Compound 4 ended at the assay's limit; the forecaster's own chance of this, stated with the estimate: 65%; the middle value lies on the limit itself.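

No size can be read for the step between compound 2 and compound 4, because both values are limits and not numbers: the limit of > 100 ug/mL in this assay, at which 4 of the 4 values shown sit. The compounds shown leave open which changes, if any, would give a measurable value in this assay.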